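From chloro to bromo on a weakly cytotoxic core

The source may report more compounds than this note shows. Statements on the series, on what has been measured and on what is new or still open speak of the compounds shown alone.

Compound 1 `CSc1nc(Br)c(C(=O)c2ccccc2)s1`: > 100000 nM (a limit)
Compound 2 `O=C(c1ccccc1)c1sc(N2CCCC2)nc1Br`: > 100000 nM (a limit)
Compound 3 `O=C(c1ccccc1)c1sc(N2CCCCC2)nc1Cl`: 91000 nM

Among the measured compounds shown here, in a functional assay on SK-MEL-28 cells (Homo sapiens) for cytotoxicity, read by MTT assay, with a stated time of 72 h (a higher number here means a weaker inhibitor, a lower number a stronger inhibitor), compound 3 gives 91000 nM, the only actual number among the three. Compound 1 and compound 2 both stand at the limit of > 100000 nM in this assay, at which 2 of the 3 values shown sit.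

Compound 4 `O=C(c1ccccc1)c1sc(N2CCCCC2)nc1Br` differs from compound 3 by bromo in place of chloro on an aromatic carbon. For the measured compounds named here, the one measured step, a step that the two limits leave unreadable from compound 1 to compound 2, exchanges a different group and has no readable size, so it offers no guide to swapping chloro for bromo. The expected change is therefore none beyond the scatter, and the estimated step is no change at the digits printed from compound 3 to compound 4 (within the scatter). Compound 4 is expected at 91000 nM, with an estimated range of 50000 nM to 170000 nM.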

Compound 4, half-maximal inhibitory concentration: 91000 nM
The estimate for compound 4 equals the measured number at the digits printed; the measured number falls inside the stated range.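

At the aromatic carbon next to the ring nitrogen, with piperidin-1-yl on the shared core, this assay gives no change at the digits printed from compound 3 to compound 4 (within the scatter), so it does not separate bromo from chloro here. With bromo held in place, the exchanges at the other substituent give an at least 1.0-fold lower number from compound 2 to compound 4 (0.04 log units; that floor lies within the scatter) and an at least 1.0-fold lower number from compound 1 to compound 4 (0.04 log units; that floor lies within the scatter). Those two floors rest on a limit and not on a number: the limit of > 100000 nM in this assay, at which 2 of the 4 values shown sit.

Going by these compounds, the true size of those two steps stays open. So does what an amine or a carboxylic acid would give at the carbon that carries the halogen.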